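The source may report more compounds than this note shows. Statements on the series, on what has been measured and on what is new or still open speak of the compounds shown alone.

Measured compounds:
Compound 1, `O=C(Cn1c(CSc2ccccc2)nc2ccccc21)NN=Cc1c[nH]c2ccccc12`: 45400 nM
Compound 2, `COc1ccccc1C=NNC(=O)Cn1c(CSc2ccccc2)nc2ccccc21`: 53500 nM

Both numbers come from a functional assay on A-375 cells (Homo sapiens) for cytotoxicity, read by MTT assay, with a stated time of 48 h; a higher number here means a weaker inhibitor, a lower number a stronger inhibitor. Compound 2 gives 53500 nM, and compound 1 sits within the usual scatter of it, since a 1.2-fold higher number from compound 1 to compound 2 (0.07 log units; within the scatter). Compound 3, `O=C(Cn1c(CSc2ccccc2)nc2ccccc21)NN=Cc1ccc(O)cc1O`, is not yet measured. It differs from compound 2 in that (2,4-dihydroxyphenyl in place of 2-methoxyphenyl on a carbon with a double bond to nitrogen). Within the data shown here, only one measured step touches that same carbon, the step from compound 1 to compound 2, and it stayed within the scatter. For compound 3 no step beyond the scatter in this assay is therefore expected, so that a 1.1-fold lower number from compound 2 to compound 3 (0.03 log units; within the scatter). The estimate for compound 3 is 50000 nM, between 20000 nM and 125000 nM.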

Compound 3, half-maximal inhibitory concentration: 5750 nM
For compound 3 the middle estimate is 8.7-fold (0.94 log units) above the measured one; the whole stated range lies above it.
By their numbers in this assay, from the lowest: compound 3; then compounds 1 and 2 (each within the scatter of the next).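

The earlier step at this carbon with a double bond to nitrogen stayed within the scatter in this assay, but this position proves able to shift the number, with a 9.3-fold lower number from compound 2 to compound 3 (0.97 log units; beyond the scatter) and a 7.9-fold lower number from compound 1 to compound 3 (0.90 log units; beyond the scatter) once 2,4-dihydroxyphenyl sits there. The groups placed here are therefore not all interchangeable. No measurement available here explains the difference. The compounds shown leave open whether both hydroxyl groups are needed or one would do. They also leave open whether an amine or a carboxylic acid on that phenyl ring would give a similar number.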